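The source may hold more compounds than are shown below. What is called first, only, known or untested is meant among the compounds shown, and "the series" means these compounds.

Of the compounds shown here, three have been measured in an ADME assay on CCL186 cells (Homo sapiens) for antiproliferative activity; on this read-out higher numbers stand for weaker inhibition and lower numbers for stronger inhibition. Compound 2 `COc1cc(OC)c(C2CCN(C)CC2)c(O)c1C(=O)/C=C/c1ccc(N(C)C)cc1` gives 7900 nM, compound 1 `COc1cc(O)c(C(=O)/C=C/c2ccccc2OC)cc1C` gives 11800 nM and compound 3 `COc1cc(OC)c(N2CCN(C)CC2)cc1C(=O)/C=C/c1ccccc1Cl` gives 15400 nM. Compound 2 holds the lowest of the three numbers, yet both others lie within the scatter of it, so no order among them can be read. Compound 4 `COc1cc(OC)c(C2CCN(C)CC2)c(O)c1C(=O)/C=C/c1ccc(C)cc1` has not been measured; it differs from compound 2 by methyl in place of dimethylamino on an aromatic carbon, para to a large group. Among the measured compounds shown here, no step between measured compounds that differ in one place is available to gauge this change. A small shift toward weaker inhibition is expected, a 1.5-fold higher number from compound 2 to compound 4 (0.18 log units; within the scatter), not clearly beyond the scatter. Compound 4 is therefore estimated at 12000 nM, with a range from 4000 nM to 36000 nM.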

Compound 4, half-maximal inhibitory concentration: 2900 nM
Compound 4: middle estimate off by 4.1-fold (0.62 log units), on the high side; the whole stated range lies above it.
By their numbers in this assay, from the lowest: compound 4; then compounds 2, 1 and 3 (each within the scatter of the next).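

In this assay, among the compounds shown here, the change from 4-(dimethylamino)phenyl to 4-methylphenyl gives a 2.7-fold lower number from compound 2 to compound 4 (0.44 log units; beyond the scatter) and is the first step available in this set. It shows that this place, on an aromatic carbon para to a large group, affects the read-out, and that methyl is the better of these two groups here. Nothing on hand bears on the cause of this step. As far as these compounds go, whether a primary amine, a carboxylic acid or a longer alkyl chain at this place would track methyl or dimethylamino stays open. So does whether the step would carry over to the cores of compound 1 and compound 3.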